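Swapping an indole for bromophenyl: what cytotoxicity to expect

A few compounds are considered here, and "the series" means these few. Any claim that something is new, unique, unknown or untested is made for them only; others in the source may bear on it.

Three compounds share one core and differ only at the far end of the molecule. Compound 1 `CC(C)N(Cc1cccc(OCCCCCC(=O)O)c1)C(=O)c1ccc(-c2cccc(Oc3ccccc3)c2)cc1` carries a phenoxy group. In an ADME assay on HepG2 cells (Homo sapiens) for cytotoxicity, read by CellTiter-Glo and resazurin assay, with a stated time of 72 h (a lower number here means that less compound is needed, a higher number that more compound is needed for the effect), compound 1 gives > 18700 nM, which is a limit of the assay rather than a number. Compound 2 `Cc1nnc(-c2cccc(-c3ccc(C(=O)N(Cc4cccc(OCCCCCC(=O)O)c4)C(C)C)cc3)c2)o1` has 5-methyl-1,3,4-oxadiazol-2-yl in place of phenoxy on an aromatic carbon; in this assay compound 2 gives > 26000 nM, again only a limit. Compound 3 `CC(C)N(Cc1cccc(OCCCCCC(=O)O)c1)C(=O)c1ccc(-c2ccc3[nH]ccc3c2)cc1` carries 1H-indol-5-yl in place of 3-(5-methyl-1,3,4-oxadiazol-2-yl)phenyl on an aromatic carbon; in this assay compound 3 gives > 26000 nM, also a limit. Compound 3 thus stands at the limit of > 26000 nM in this assay, at which 2 of the 3 values shown sit, while the remaining value sits at the limit of > 18700 nM in this assay, at which 1 of the 3 values shown sits. The step that the two limits leave unreadable from compound 1 to compound 2 and the step that the two limits leave unreadable from compound 2 to compound 3 each have a limit at both ends and so have no readable size.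

Compound 4 `CC(C)N(Cc1cccc(OCCCCCC(=O)O)c1)C(=O)c1ccc(-c2cccc(Br)c2)cc1` is the compound still to be measured; the change is 3-bromophenyl in place of 1H-indol-5-yl on an aromatic carbon. Among the compounds with values here, no measured step offers a readable size, so nothing points to an effect beyond the scatter. Compound 4 is expected to give 30000 nM, within 10000 nM to 100000 nM. The step that the limit leaves unreadable from compound 3 to compound 4 is expected to stay within the scatter, and most likely only a limit will again be reported.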

Compound 4, half-maximal effective concentration: > 26000 nM
Compound 4: no number, only a limit (the forecaster's own chance of this, stated with the estimate: 80%); the middle value does not contradict the limit.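

Compound 4 gives only a limit in this assay, as do compound 1, compound 2 and compound 3, so none of the steps from those three compounds to compound 4 can be read. The compounds shown leave open how much of any of them is needed for the half-maximal effect, and whether these end groups change cytotoxicity at all.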